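A few compounds are considered here, and "the series" means these few. Any claim that something is new, unique, unknown or untested is made for them only; others in the source may bear on it.

Working notes on the series. Compound 1 `CC(=O)OC/C1=C/C[C@](C)(CCC=C(C)C)/C=C/[C@@H](OC(=O)C=C(C)C)[C@](C)(O)/C=C/C1=O` serves as the reference point. Among the compounds with values here, in a functional assay on HL-60 cells (Homo sapiens) for antiproliferative activity, read by MTT assay, with a stated time of 48 h (on this read-out lower numbers stand for stronger inhibition and higher numbers for weaker inhibition), compound 1 gives 2950 nM, the lowest of the two numbers measured so far. Compound 2 `CC(=O)OC/C1=C/C[C@](C)(CCC=C(C)C)/C=C/[C@@H](OC(=O)C=C(C)C)[C@](C)(OC(C)=O)/C=C/C1=O` carries an acetyl in place of hydrogen on an oxygen on a saturated carbon and gives 3480 nM in this assay; the step of a 1.2-fold higher number from compound 1 to compound 2 (0.07 log units; within the scatter) lies within the scatter. Compound 3 `CC(C)=CCC[C@]1(C)/C=C/[C@@H](OC(=O)C=C(C)C)[C@](C)(O)CCC(=O)/C(CO)=C\C1` returns only a limit in this assay, > 40000 nM; this is the limit of > 40000 nM in this assay, at which 1 of the 3 values shown sits. Within the data shown here, compound 3 differs from compound 1 in more than one place, so its limit shows only that the two values lie apart, not which change is responsible.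

Compound 4 `CC(C)=CCC[C@]1(C)/C=C/[C@@H](OC(=O)C=C(C)C)[C@](C)(O)/C=C/C(=O)/C(CN=[N+]=[N-])=C\C1` is not yet measured. Relative to compound 1 the change is azido in place of acetoxy on a saturated chain carbon bound to a double-bonded ring carbon. Among the measured compounds shown here, no measured step touches the acetoxy group or introduces an azido group; the only single-point step in hand, a 1.2-fold higher number from compound 1 to compound 2 (0.07 log units; within the scatter), concerns a different oxygen and stayed within the scatter. The series therefore gives no basis for expecting a shift beyond the scatter in this assay in either direction, and the estimate for compound 4 is placed near compound 1 with a broad range for an untested group. Compound 4 is expected to give 3500 nM in this assay, within 1200 nM to 12000 nM. The expected step of a 1.2-fold higher number from compound 1 to compound 4 (0.07 log units; within the scatter) is accordingly within the scatter.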

Compound 4, half-maximal inhibitory concentration: 910 nM
For compound 4 the middle estimate is 3.8-fold (0.59 log units) above the measured one; the measured number lies below the stated range.
By their numbers in this assay, from the lowest: compound 4; then compounds 1 and 2 (each within the scatter of the next). At a limit, above all of these: compound 3.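

Within the data shown here, the step at this place, a 3.2-fold lower number from compound 1 to compound 4 (0.51 log units; beyond the scatter), is the first single-place change in this assay to go beyond the scatter; the earlier step, a 1.2-fold higher number from compound 1 to compound 2 (0.07 log units; within the scatter), concerned a different oxygen and stayed within it. The acetoxy group on this saturated chain carbon bound to a double-bonded ring carbon is therefore not required for the activity of compound 1, and the position tolerates an azido group, made up of nitrogen alone, with a modest move towards stronger inhibition. Nothing shown gives a measured reason for this step, so it stays an observation tied to this single pair.

Open, on these data alone, is whether an aminomethyl or a chloromethyl group at this place would track azidomethyl, so the step cannot yet be assigned to azido itself rather than to the departure of acetoxy. Also open, as far as these compounds go, is whether acetoxymethyl to azidomethyl would give a step of similar size on the acetylated oxygen of compound 2, and whether it would hold in cells other than those of this assay.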